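The source may report more compounds than this note shows. Statements on the series, on what has been measured and on what is new or still open speak of the compounds shown alone.

Working notes on the series. Compound 1 `CC1=CCC[C@](C)(CC/C(C)=C/CC2=C(O)C(=O)C=C(N[C@H](C(=O)O)[C@@H](C)O)C2=O)[C@@H]1C` sits at the edge of an ADME assay on L1210 cells (Mus musculus) for cytotoxicity, with a stated time of 48 h; a lower number here means a stronger inhibitor, a higher number a weaker inhibitor: in this assay compound 1 gives > 10 ug/mL, a limit of the measurement and not a number. Within the data shown here, compound 2 `COC1=CC(=O)C(O)=C(C/C=C(\C)CC[C@@]2(C)CCC=C(C)[C@H]2C)C1=O`, with methoxy in place of (1-carboxy-2-hydroxypropyl)amino on a double-bonded ring carbon, gives 2 ug/mL in this assay, and the step of an at least 5.0-fold lower number from compound 1 to compound 2 (0.69 log units; beyond the scatter) is the only measured step in the set. Among the measured compounds shown here, compound 3 `CC1=CCC[C@H]2[C@](C)(CC3=C(O)C(=O)C=C(N[C@@H](CO)C(=O)O)C3=O)[C@@H](C)CC[C@]12C`, built on another core, gives 3.8 ug/mL in this assay; no step from compound 1 or compound 2 to it is counted.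

Compound 4 `CC1=CCC[C@](C)(CC/C(C)=C/CC2=C(O)C(=O)C=C(NCC(=O)O)C2=O)[C@@H]1C` keeps the core of compound 1 and differs from it by hydrogen in place of 1-hydroxyethyl on a saturated chain carbon bound to an amine nitrogen and a carbonyl carbon. For the measured compounds named here, the one measured step, from compound 1 to compound 2, replaces the whole (1-carboxy-2-hydroxypropyl)amino group with methoxy rather than 1-hydroxyethyl with hydrogen, so it bears only loosely on this change. The mark the limit of > 10 ug/mL in this assay, at which 1 of the 3 values shown sits, shows that compound 1 is known only as a limit, which leaves the size of any step from it open in the numbers. A step of little size, within the scatter or just beyond it, is expected, in either direction. The estimate for compound 4 in this assay is 9 ug/mL, between 3 ug/mL and 25 ug/mL, so that the expected step is an at least 1.1-fold lower number from compound 1 to compound 4 (0.04 log units; that floor lies within the scatter).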

Compound 4, half-maximal inhibitory concentration: 3.5 ug/mL
Beside the measured number, compound 4's estimate is 2.6-fold (0.41 log units) above it; the range from low to high includes it.
By their numbers in this assay, from the lowest: compounds 2, 4 and 3 (each within the scatter of the next). At a limit, above all of these: compound 1.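

In this assay, the change at the saturated chain carbon bound to an amine nitrogen and a carbonyl carbon, with the rest of compound 1 kept, gives an at least 2.8-fold lower number from compound 1 to compound 4 (0.45 log units; beyond the scatter); the 1-hydroxyethyl group alone is thus enough to separate these two compounds beyond the scatter, which the earlier exchange of the whole (1-carboxy-2-hydroxypropyl)amino group could not show. The exchange of methoxy for (carboxymethyl)amino on a double-bonded ring carbon gives a 1.8-fold higher number from compound 2 to compound 4 (0.24 log units; within the scatter), so among the compounds on this core, a nitrogen-linked group at that ring carbon does not by itself separate a compound from the methoxy compound. The first of these steps has only a floor, and compound 1 remains a limit and not a number: the limit of > 10 ug/mL in this assay, at which 1 of the 4 values shown sits.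

The compounds shown leave open which part of 1-hydroxyethyl accounts for the step, and a methyl group on that chain carbon would separate the hydroxyl from the carbon chain. From the compounds shown here alone, the role of the carboxylic acid in (carboxymethyl)amino is also open, and a primary amide in its place would bear on it.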